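Benzylidene penam series: ester variation and the unmeasured benzhydryl ester

This account rests on a few compounds, and the source may have more. Where it says the series, first, only, none or still open, it means among the compounds named here.

Three compounds of a shared core have been run in a functional assay on A-375 cells (Homo sapiens) for cytotoxicity, read by MTT assay, with a stated time of 48 h; a lower number here means a stronger inhibitor, a higher number a weaker inhibitor. Compound 1 `CC1(C)S[C@@H]2/C(=C\C(=O)c3ccccc3)C(=O)N2[C@H]1C(=O)OC(c1ccccc1)c1ccccc1` gives 22800 nM. Compound 2 `CC1(C)S[C@@H]2/C(=C\C(=O)c3ccc(Cl)cc3)C(=O)N2[C@H]1C(=O)OC(c1ccccc1)c1ccccc1` gives 48600 nM; the step of a 2.1-fold higher number from compound 1 to compound 2 (0.33 log units; beyond the scatter) goes with chloro in place of hydrogen on an aromatic carbon. Compound 3 `CC1(C)S[C@@H]2/C(=C\C(=O)OCc3ccccc3)C(=O)N2[C@H]1C(=O)OC(c1ccccc1)c1ccccc1` gives 7100 nM, the lowest of the three numbers, with compound 1 nearest and compound 2 furthest. The steps of a 3.2-fold lower number from compound 1 to compound 3 (0.51 log units; beyond the scatter) and a 6.8-fold lower number from compound 2 to compound 3 (0.84 log units; beyond the scatter) both go with the benzyloxy ester in place of the aryl ketone on the carbonyl carbon.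

Compound 4 `CC1(C)S[C@@H]2/C(=C\C(=O)OC(c3ccccc3)c3ccccc3)C(=O)N2[C@H]1C(=O)OC(c1ccccc1)c1ccccc1` differs from compound 3 by phenyl in place of hydrogen on a saturated chain carbon bound to an aromatic carbon and an oxygen next to a carbonyl group. For the measured compounds named here, no measured step touches this saturated chain carbon; the two steps into compound 3 concern what sits on the carbonyl carbon, and the one remaining step concerns a substituent on the aromatic ring of the ketone. There is therefore nothing in the numbers that points to a direction for adding a phenyl here. The expectation is that compound 4 stays near compound 3 in this assay, with the step of a 1.2-fold lower number from compound 3 to compound 4 (0.07 log units; within the scatter) expected to lie within the scatter. Compound 4 is estimated at 6000 nM, within 1800 nM to 20000 nM.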

Compound 4, half-maximal inhibitory concentration: 9100 nM
The estimate for compound 4 lay 1.5-fold (0.18 log units) below the measured number; the measured number falls inside the stated range.
By their numbers in this assay, from the lowest: compounds 3 and 4 (each within the scatter of the next); then compound 1; then compound 2.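

In this assay, the saturated chain carbon bound to an aromatic carbon and an oxygen next to a carbonyl group takes a phenyl in place of hydrogen with a 1.3-fold higher number from compound 3 to compound 4 (0.11 log units; within the scatter), so six further heavy atoms at this position leave compound 4 within the scatter of compound 3. The earlier steps, which concern the aromatic ring of the ketone or the group on the carbonyl carbon, all lie beyond the scatter; this step, at a different place, is the one shown that does not separate its two compounds. No measurement at hand offers an explanation for this result.

Going by these compounds, whether this carbon gives a similar reading with a group other than phenyl, such as an amine, a carboxylic acid or a longer chain, remains open. Also open, on these data alone, is whether chloro in place of hydrogen on an aromatic carbon of the ester would repeat the step on the ketone series, a 2.1-fold higher number from compound 1 to compound 2 (0.33 log units; beyond the scatter).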